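The compounds below may be only part of what the source reports. "The series", "measured", "known", "first", "only" and "open" are said of these compounds alone.

Measured compounds and their values:

Compound 1, `C=CC(=O)Nc1cccc(NC(=O)CSc2nc(Nc3ccccc3)c3ccccc3n2)c1`: 10200 nM
Compound 2, `C=CC(=O)Nc1cccc(NC(=O)CSc2nc(Nc3cccc(Br)c3)c3ccccc3n2)c1`: 19400 nM

Both compounds share one core and were tested in a functional assay on MDA-MB-231 cells (Homo sapiens) for inhibition, read by MTT assay, with a stated time of 72 h; on this read-out lower numbers stand for stronger inhibition and higher numbers for weaker inhibition. Compound 1 gives 10200 nM in this assay, and compound 2 gives 19400 nM. Compound 2 is not separated from compound 1 beyond the usual scatter, since the step that puts a bromo on one aromatic carbon reads a 1.9-fold higher number from compound 1 to compound 2 (0.28 log units; within the scatter).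

Compound 3, `C=CC(=O)Nc1cccc(NC(=O)CSc2nc(Nc3ccc(Br)cc3)c3ccccc3n2)c1`, has not yet been measured. It differs from compound 2 only in the placement of that bromine: 4-bromophenyl in place of 3-bromophenyl on a nitrogen on an aromatic ring. For the measured compounds named here, no measured step moves a bromo from one position of this ring to another; the only step available, a 1.9-fold higher number from compound 1 to compound 2 (0.28 log units; within the scatter), introduces the bromo and stays within the scatter. There is therefore no basis in the data for expecting a step beyond the scatter in either direction in this assay.

Compound 3 is accordingly expected to give 16000 nM, with a range of 5000 nM to 50000 nM. The expected step from compound 2 to compound 3 is a 1.2-fold lower number from compound 2 to compound 3 (0.08 log units; within the scatter), which is within the scatter.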

Compound 3, half-maximal inhibitory concentration: 17300 nM
Beside the measured number, compound 3's estimate is 1.1-fold (0.03 log units) below it, within the range that was stated.
By their numbers in this assay, from the lowest: compounds 1, 3 and 2 (each within the scatter of the next).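

Moving the bromine, with 4-bromophenyl in place of 3-bromophenyl on a nitrogen on an aromatic ring, gives in this assay a 1.1-fold lower number from compound 2 to compound 3 (0.05 log units; within the scatter) and so makes no readable difference in this test. The earlier pair showed only that a bromo at one placement stays within the scatter of the hydrogen compound; the new placement gives the same kind of result, with a 1.7-fold higher number from compound 1 to compound 3 (0.23 log units; within the scatter) for the same swap of hydrogen for bromo. Across these three compounds, then, neither the presence of a bromo on this ring nor either of its two placements separates one compound from another, and nothing measured here bears on why the numbers stay so close.

The compounds shown leave open whether a group other than bromo on this ring, such as a methoxy group, an amine or a carboxylic acid, would give a step beyond the scatter. They also leave open what a longer chain on that nitrogen, in place of the aromatic ring, would do to the number.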